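The source may hold more compounds than are shown below. What is called first, only, known or untested is meant among the compounds shown, and "the series" means these compounds.

In an ADME assay on Caco-2 cells (Homo sapiens) for permeability, in the apical to basolateral direction (on this read-out higher numbers stand for higher permeability and lower numbers for lower permeability), compound 3 `Cn1cncc1CN1CC(N(CC2CCN(C(=O)N3CCCCC3)CC2)S(=O)(=O)c2ccccn2)Cc2cc(C#N)ccc21` gives 0.6 10^-6 cm/s, the highest of the three numbers shown, although that position rests on nothing beyond the scatter: a 1.2-fold higher number from compound 1 to compound 3 (0.08 log units; within the scatter) and a 1.2-fold higher number from compound 2 to compound 3 (0.08 log units; within the scatter) are both small. Compound 1 `Cn1cncc1CN1CC(N(CC2CCN(C(=O)c3ccc(Cl)cc3)CC2)S(=O)(=O)c2ccccn2)Cc2cc(C#N)ccc21` gives 0.5 10^-6 cm/s and compound 2 `CCC(=O)N1CCC(CN(C2Cc3cc(C#N)ccc3N(Cc3cncn3C)C2)S(=O)(=O)c2ccccn2)CC1` gives 0.5 10^-6 cm/s, with no change at the digits printed from compound 1 to compound 2 (within the scatter). Compound 4 `Cn1cncc1CN1CC(N(CC2CCN(C(=O)C3CC3)CC2)S(=O)(=O)c2ccccn2)Cc2cc(C#N)ccc21` differs from compound 3 by cyclopropyl in place of piperidin-1-yl on a carbonyl carbon. All three measured steps exchanged the group on this same carbonyl carbon, and none of them moved the number beyond the scatter, so a fourth exchange at that position is expected to behave alike, with a 1.1-fold lower number from compound 3 to compound 4 (0.04 log units; within the scatter). For compound 4 the estimated value in this assay is 0.55 10^-6 cm/s, expected to fall between 0.3 10^-6 cm/s and 1 10^-6 cm/s.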

Compound 4, apparent permeability: 0.5 10^-6 cm/s
Compound 4: middle estimate off by 1.1-fold (0.04 log units), on the high side; the range from low to high includes it.
By their numbers in this assay, from the lowest: compounds 1, 2, 4 and 3 (each within the scatter of the next).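

With cyclopropyl on this carbonyl carbon, this assay shows a 1.2-fold lower number from compound 3 to compound 4 (0.08 log units; within the scatter) and no change at the digits printed from compound 2 to compound 4 (within the scatter) as well as no change at the digits printed from compound 1 to compound 4 (within the scatter) for the same kind of exchange. A three-membered carbon ring therefore joins piperidin-1-yl, ethyl and 4-chlorophenyl, and all four groups give numbers within the scatter of one another. Nothing available explains this flatness. Going by these compounds, whether a group bearing an amine or a carboxylic acid on this carbonyl carbon would also stay within the scatter remains open, as does the effect of any change to the shared core.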